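The source may report more compounds than this note shows. Statements on the series, on what has been measured and on what is new or still open speak of the compounds shown alone.

In a functional assay on MIA PaCa-2 cells (Homo sapiens) for inhibition, read by MTT assay, with a stated time of 48 h, tested at 10 uM (a higher number here means more inhibition of growth at the concentration tested, a lower number less inhibition of growth), compound 1 `Cc1cc(=O)c2c(O)cc(OCc3ccc([N+](=O)[O-])cc3)c([C@H]3CCN(C)C[C@H]3O)c2o1` gives 12%. In the same assay compound 2 `Cc1cc(=O)c2c(O)cc(OC/C=C/c3ccccc3)c([C@H]3CCN(C)C[C@H]3O)c2o1` gives 11%, which leaves compound 2 level with compound 1 within the scatter. For the measured compounds named here, these are the only two numbers so far. Compound 3 `Cc1cc(=O)c2c(O)cc(OCc3ccco3)c([C@H]3CCN(C)C[C@H]3O)c2o1` keeps the shared core and changes one group: furan-2-yl in place of 2-phenylethenyl on a saturated chain carbon bound to an oxygen on an aromatic ring. Going by the values given here, one measured step bears on this place, a number 1 percentage points lower from compound 1 to compound 2 (within the scatter), where 2-phenylethenyl took the place of 4-nitrophenyl on a saturated chain carbon bound to an oxygen on an aromatic ring. That step stays within the scatter. Among the compounds with values here, no compound with furan-2-yl has a measured value yet, so the data give no direction, and no step beyond the scatter is expected in this assay. The expected step is a number 1 percentage points higher from compound 2 to compound 3 (within the scatter). For compound 3 the estimated value is 12%, with an expected range of 2% to 25%.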

Compound 3, percent growth inhibition at one concentration: 7%
Compound 3: the middle estimate sits 5 percentage points above what was measured; the range from low to high includes it.
By their numbers in this assay, from the lowest: compounds 3, 2 and 1 (each within the scatter of the next).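

With furan-2-yl on a saturated chain carbon bound to an oxygen on an aromatic ring, a five-membered aromatic ring with a hetero atom now occupies this position, and this assay shows a number 4 percentage points lower from compound 2 to compound 3 (within the scatter) and also a number 5 percentage points lower from compound 1 to compound 3 (within the scatter). The position has therefore taken 4-nitrophenyl, 2-phenylethenyl and furan-2-yl with all three compounds level within the scatter, so the exchange of a six-membered aromatic ring of carbon only for this smaller ring separates none of them in this read-out. No measurement bears on why the numbers stay level.

The compounds shown leave open whether an amine or a carboxylic acid at this position would give a step beyond the scatter. They also leave open whether changes elsewhere on the shared core would do so.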